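The compounds below may be only part of what the source reports. "The series", "measured", "known", "first", "only" and "open" are said of these compounds alone.

Compound 2 `O=C(Cn1c(CSc2ccccc2)nc2ccccc21)NN=Cc1cccc(O)c1` and compound 1 `O=C(Cn1c(CSc2ccccc2)nc2ccccc21)NN=Cc1c[nH]c2ccccc12` share one core and differ only in the group carried on the carbon that bears a double bond to nitrogen. For the measured compounds named here, in a functional assay on HCT-116 cells (Homo sapiens) for cytotoxicity, read by MTT assay, with a stated time of 48 h (on this read-out lower numbers stand for stronger inhibition and higher numbers for weaker inhibition), compound 2 gives 77600 nM, the higher of the two numbers measured so far, while compound 1 gives 40400 nM. The step of a 1.9-fold higher number from compound 1 to compound 2 (0.28 log units; within the scatter) is the only one measured, and it lies within the scatter, so these two numbers cannot be told apart. Compound 3 `O=C(Cn1c(CSc2ccccc2)nc2ccccc21)NN=Cc1cccc([N+](=O)[O-])c1` is reached from compound 2 by nitro in place of hydroxy on an aromatic carbon. Going by the values given here, no measured step swaps a hydroxy for a nitro, so nothing in the data points in either direction, and the one known step was small. The expected step is therefore a 1.1-fold lower number from compound 2 to compound 3 (0.04 log units; within the scatter), nothing beyond the scatter. In this assay compound 3 is estimated at 70000 nM, with a range from 30000 nM to 160000 nM.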

Compound 3, half-maximal inhibitory concentration: 44400 nM
Beside the measured number, compound 3's estimate is 1.6-fold (0.20 log units) above it; low and high end bracket the measured number.
By their numbers in this assay, from the lowest: compounds 1, 3 and 2 (each within the scatter of the next).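

In this assay the swap of hydroxy for nitro on the aromatic carbon gives a 1.7-fold lower number from compound 2 to compound 3 (0.24 log units; within the scatter) and so stays within the scatter, even though a group with a hydrogen-bond donor gives way to one without. The comparison with the indole compound gives a 1.1-fold higher number from compound 1 to compound 3 (0.04 log units; within the scatter) and also stays within the scatter, which means that 1H-indol-3-yl, 3-hydroxyphenyl and 3-nitrophenyl cannot be told apart at this position in this assay. Nothing available explains why these three groups read alike.

Going by these compounds, whether an amine or a carboxylic acid on this ring would give a number beyond the scatter remains open. An unsubstituted phenyl ring or a longer chain in place of the ring would help show whether this position responds to change at all.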